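Trifluoromethoxy for Trifluoromethyl in a Growth Inhibition Series

This account rests on a few compounds, and the source may have more. Where it says the series, first, only, none or still open, it means among the compounds named here.

In a functional assay on DWD cells (Homo sapiens) for inhibition, read by sulforhodamine B assay (on this read-out higher numbers stand for weaker inhibition of growth and lower numbers for stronger inhibition of growth), compound 1 (`Oc1cccc2[nH]c(-c3ccc(-c4ccc(-c5ccccc5)cc4)cc3)nc12`) gives 9680 nM. Compound 2 (`Oc1cccc2[nH]c(-c3ccc(-c4ccc(-c5ccc(F)cc5)cc4)cc3)nc12`) gives 22200 nM, and compound 3 (`Oc1cccc2[nH]c(-c3ccc(-c4ccc(-c5ccc(C(F)(F)F)cc5)cc4)cc3)nc12`) gives 3180 nM. Compound 3 therefore has the lowest of the three numbers, which on this read-out means the strongest inhibition of growth, and its steps to both others lie beyond the scatter.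

The next compound, compound 4 (`Oc1cccc2[nH]c(-c3ccc(-c4ccc(-c5ccc(OC(F)(F)F)cc5)cc4)cc3)nc12`), carries trifluoromethoxy in place of trifluoromethyl on an aromatic carbon.

Among the measured compounds shown here, three measured steps bear on this change, each a swap of the substituent on an aromatic carbon. Fluoro in place of hydrogen gave a 2.3-fold higher number from compound 1 to compound 2 (0.36 log units; beyond the scatter), trifluoromethyl in place of hydrogen gave a 3.0-fold lower number from compound 1 to compound 3 (0.48 log units; beyond the scatter), and trifluoromethyl in place of fluoro gave a 7.0-fold lower number from compound 2 to compound 3 (0.84 log units; beyond the scatter). These steps are modest and run in both directions, and none of them replaces trifluoromethyl with trifluoromethoxy. For the measured compounds named here, no step clearly beyond the scatter is therefore expected in this assay, with only a slight lean towards a higher number. The expected change is a 1.3-fold higher number from compound 3 to compound 4 (0.12 log units; within the scatter). Compound 4 is estimated at 4200 nM, with an expected range of 1500 nM to 11000 nM.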

Compound 4, concentration for 50% growth inhibition: 3100 nM
The estimate for compound 4 lay 1.4-fold (0.13 log units) above the measured number, within the range that was stated.
By their numbers in this assay, from the lowest: compounds 4 and 3 (each within the scatter of the next); then compound 1; then compound 2.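

In this assay the swap of trifluoromethyl for trifluoromethoxy, on an aromatic carbon para to a large group, gives a 1.0-fold lower number from compound 3 to compound 4 (0.01 log units; within the scatter) and so adds an oxygen to the substituent with no change that this read-out can separate from the scatter. Compound 4 also keeps the standing that compound 3 held in this assay, with a 7.2-fold lower number from compound 2 to compound 4 (0.85 log units; beyond the scatter) on the swap from fluoro and a 3.1-fold lower number from compound 1 to compound 4 (0.49 log units; beyond the scatter) on the swap from hydrogen. Among the compounds shown here, two substituents, trifluoromethyl and trifluoromethoxy, now stand at a lower number than hydrogen at this position, where the earlier compounds offered only one, and compound 2, with fluoro, goes against any reading that a fluorine-bearing group as such lowers the number.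

The compounds shown leave open whether the level shared by compound 3 and compound 4 extends to groups without fluorine, such as a methoxy, an amine or a carboxylic acid, or to a longer chain at this position. Nothing given here accounts for why the added oxygen leaves no readable difference.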